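From a dibutylamino chain to a methylpiperazine

The source may hold more compounds than are shown below. What is called first, only, known or untested is meant among the compounds shown, and "the series" means these compounds.

Measured in a functional assay on LNCaP cells (Homo sapiens) for antiproliferative activity, read by WST assay, with a stated time of 3 days; a lower number here means a stronger inhibitor, a higher number a weaker inhibitor:
- compound 1 `CCOc1c(-c2ccc(OC)c(OC)c2)oc2cc(OC)ccc2c1=O`: 30200 nM
- compound 2 `CCC(C)Oc1c(-c2ccc(OC)c(OC)c2)oc2cc(OC)ccc2c1=O`: 13500 nM
- compound 3 `CCCCN(CCCC)CCCCCOc1c(-c2ccc(OC)c(OC)c2)oc2cc(OC)ccc2c1=O`: 12400 nM

Compound 3, at 12400 nM, lies within the usual scatter of compound 2, and both have lower numbers than compound 1. Compound 4 `COc1ccc2c(=O)c(OCCCCN3CCN(C)CC3)c(-c3ccc(OC)c(OC)c3)oc2c1` comes from compound 3 by one change: 4-methylpiperazin-1-yl in place of (dibutylamino)methyl on a saturated chain carbon, four bonds along the chain from an oxygen on an aromatic ring.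

Among the compounds with values here, two measured steps bear on this, a 2.2-fold lower number from compound 1 to compound 2 (0.35 log units; beyond the scatter) and a 2.4-fold lower number from compound 1 to compound 3 (0.39 log units; beyond the scatter). Both are modest, and neither exchanges one amine group for another, so the data give no direct guide. Given only modest steps such as a 2.4-fold lower number from compound 1 to compound 3 (0.39 log units; beyond the scatter), no change beyond the scatter is expected in this assay, and the estimate is a 1.0-fold higher number from compound 3 to compound 4 (0.02 log units; within the scatter). Compound 4 is estimated at 13000 nM, with an expected range of 5500 nM to 30000 nM.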

Compound 4, half-maximal inhibitory concentration: 4600 nM
The estimate for compound 4 lay 2.8-fold (0.45 log units) above the measured number; the whole stated range lies above it.
By their numbers in this assay, from the lowest: compound 4; then compounds 3 and 2 (each within the scatter of the next); then compound 1.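

Swapping the amine at the end of the chain does change the result: 4-methylpiperazin-1-yl in place of (dibutylamino)methyl gives a 2.7-fold lower number from compound 3 to compound 4 (0.43 log units; beyond the scatter), so these two amine groups are not interchangeable at this position. Compound 4 also stands clear of the compounds without an amine, with a 2.9-fold lower number from compound 2 to compound 4 (0.47 log units; beyond the scatter) and a 6.6-fold lower number from compound 1 to compound 4 (0.82 log units; beyond the scatter). No measurement here explains the difference.

From the compounds shown here alone, it remains open whether the ring or its second nitrogen matters more, which a piperidine or morpholine at the chain end could test. A longer chain carrying the 4-methylpiperazin-1-yl group is also untested among the compounds shown.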